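Swapping trifluoromethyl for chloro on the aryl ring

The compounds below may be only part of what the source reports. "The series", "measured", "known", "first", "only" and "open" are said of these compounds alone.

Three compounds share one core and differ only in a single group on the aryl ring. Compound 1 `CCCC(C)n1c(CC)nc2c(-c3ccc(C(C)(C)O)cc3Cl)ccnc21` carries a 1-hydroxy-1-methylethyl group there, and in an assay for binding affinity to Corticotropin releasing factor receptor (Rattus norvegicus) (a higher number here means a weaker inhibitor, a lower number a stronger inhibitor), compound 1 gives 24 nM. Compound 2 `CCCC(C)n1c(CC)nc2c(-c3ccc(C(C)OC)cc3Cl)ccnc21` gives 3.5 nM in this assay, a change of a 6.9-fold lower number from compound 1 to compound 2 (0.84 log units; beyond the scatter). Compound 3 `CCCC(C)n1c(CC)nc2c(-c3ccc(C(F)(F)F)cc3Cl)ccnc21` gives 1.1 nM, the lowest of the three numbers, reached by a 22-fold lower number from compound 1 to compound 3 (1.34 log units; beyond the scatter) and by a 3.2-fold lower number from compound 2 to compound 3 (0.50 log units; beyond the scatter). Compound 4 `CCCC(C)n1c(CC)nc2c(-c3ccc(Cl)cc3Cl)ccnc21` takes the next step: chloro in place of trifluoromethyl on an aromatic carbon. Among the compounds with values here, no measured step exchanges trifluoromethyl for chloro, so the three known steps only show that altering this one group has moved the number beyond the scatter each time. A shift beyond the scatter is therefore plausible, but its direction is not settled by the data. Compound 4 is expected to give 3 nM, with a range from 0.8 nM to 12 nM. That expectation amounts to a 2.7-fold higher number from compound 3 to compound 4 (0.44 log units; beyond the scatter), a modest change.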

Compound 4, inhibition constant: 0.5 nM
Compound 4: middle estimate off by 6.0-fold (0.78 log units), on the high side; measured number outside the range, below it.
By their numbers in this assay, from the lowest: compound 4; then compound 3; then compound 2; then compound 1.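

Chloro, a single heavy atom, gives a lower number than the four heavy atoms of trifluoromethyl (a 2.2-fold lower number from compound 3 to compound 4 (0.34 log units; beyond the scatter)), so the lowest number in this assay here does not depend on the larger group at this position. The gaps to the other two groups are wider (a 7.0-fold lower number from compound 2 to compound 4 (0.85 log units; beyond the scatter); a 48-fold lower number from compound 1 to compound 4 (1.68 log units; beyond the scatter)), which places chloro ahead of all three other groups in this set, with compound 4 the most potent of the four compounds. No supporting measurement is available to explain this order.

From the compounds shown here alone, whether a bromo group, a methyl group, an amine or a carboxylic acid at this position would give a lower or a higher number remains open. Also open, going by these compounds, is whether the same order of groups would hold on a different core.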